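Working notes: replacing 4-fluorophenyl in compound 3

A few compounds are considered here, and "the series" means these few. Any claim that something is new, unique, unknown or untested is made for them only; others in the source may bear on it.

Among the compounds with values here, in a functional assay on MCF7 cells (Homo sapiens) for cytotoxicity, read by MTT assay, with a stated time of 72 h (a lower number here means a stronger inhibitor, a higher number a weaker inhibitor), compound 3 `CNC(=O)c1cc(Oc2ccc(C(=O)/C=C/c3ccc(F)cc3)cc2)ccn1` gives 28500 nM, the highest of the three numbers so far. Compound 1 `CNC(=O)c1cc(Oc2ccc(C(=O)/C=C/c3cccc(Br)c3)cc2)ccn1` gives 10400 nM and compound 2 `CNC(=O)c1cc(Oc2ccc(C(=O)/C=C/c3ccc(C#N)cc3)cc2)ccn1` gives 9520 nM. These two values lie within the scatter of each other, as a 1.1-fold lower number from compound 1 to compound 2 (0.04 log units; within the scatter) shows.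

Compound 4 `CNC(=O)c1cc(Oc2ccc(C(=O)/C=C/c3ccc(Cl)cc3Cl)cc2)ccn1` carries 2,4-dichlorophenyl in place of 4-fluorophenyl on a double-bonded chain carbon bound to a double-bonded chain carbon.

Two measured changes at this place bear on it: a 2.7-fold higher number from compound 1 to compound 3 (0.44 log units; beyond the scatter) and a 3.0-fold higher number from compound 2 to compound 3 (0.48 log units; beyond the scatter). Both are modest and beyond the scatter, and in both the 4-fluorophenyl compound has the higher number. Within the data shown here, no measured compound carries 2,4-dichlorophenyl, so the transfer is loose. A modest step to a lower number, similar in size to those two, is expected. The expected step is a 2.4-fold lower number from compound 3 to compound 4 (0.38 log units; beyond the scatter). The estimate for compound 4 is 12000 nM, with an expected range of 5000 nM to 28000 nM.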

Compound 4, half-maximal inhibitory concentration: 3990 nM
Beside the measured number, compound 4's estimate is 3.0-fold (0.48 log units) above it, outside the stated range (below it).
By their numbers in this assay, from the lowest: compound 4; then compounds 2 and 1 (each within the scatter of the next); then compound 3.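

In this assay, within the data shown here, this position can shift the number further than the earlier compounds showed, with a 7.1-fold lower number from compound 3 to compound 4 (0.85 log units; beyond the scatter) as the largest step so far. 2,4-Dichlorophenyl also separates from the two earlier compounds that lay within the scatter of each other, with a 2.4-fold lower number from compound 2 to compound 4 (0.38 log units; beyond the scatter) and a 2.6-fold lower number from compound 1 to compound 4 (0.42 log units; beyond the scatter), so compound 4 has the lowest number of the four. Nothing shown gives a reason for these steps.

The compounds shown leave open whether the lower number depends on both chlorines or on one alone, which 2-chlorophenyl and 4-chlorophenyl at this place would help separate. They also leave open how this position responds to a group of another kind, such as an aminophenyl or a carboxylic acid on the phenyl ring.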